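Acetyl to dimethylamino on the pendant phenyl ring

This account rests on a few compounds, and the source may have more. Where it says the series, first, only, none or still open, it means among the compounds named here.

Measured so far:
compound 1 `COc1cc(C)cc(-c2c(-c3ccnc(-c4ccc(C(C)=O)cc4)c3)cnn2CC#N)c1` — 4050 nM
compound 2 `COc1cc(C)cc(-c2nn(CC#N)cc2-c2ccc(-c3cccc(C(C)=O)c3)nc2)c1` — 4360 nM
compound 3 `Cc1cc(O)cc(-c2nn(CC#N)cc2-c2ccnc(-c3ccc(N(C)C)cc3)c2)c1` — 3050 nM

In a functional assay on UACC-62 cells (Homo sapiens) for inhibition, read by sulforhodamine B assay, with a stated time of 48 h (on this read-out higher numbers stand for weaker inhibition of growth and lower numbers for stronger inhibition of growth), compound 1 gives 4050 nM, the second highest of the three numbers. Its nearest neighbour is compound 2, which in this assay gives 4360 nM; the gap lies within the scatter. The furthest is compound 3, which gives 3050 nM, again within the scatter of compound 1. The three numbers therefore sit together and give no order among them.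

The step under study leads from compound 1 to compound 4 `COc1cc(C)cc(-c2c(-c3ccnc(-c4ccc(N(C)C)cc4)c3)cnn2CC#N)c1`. The change is dimethylamino in place of acetyl on an aromatic carbon. For the measured compounds named here, no step between measured compounds with this single change has been recorded. Compound 3 also carries a dimethylamino group on its pendant phenyl ring but differs from compound 1 elsewhere as well, so its value can only be read as a loose pointer, and it shows no separation from compound 1 beyond the scatter.

On that basis the step from compound 1 to compound 4 is expected to be a 1.2-fold lower number from compound 1 to compound 4 (0.06 log units; within the scatter), with no direction beyond the scatter. Compound 4 is estimated at 3500 nM, within a range of 1500 nM to 8000 nM.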

Compound 4, concentration for 50% growth inhibition: 61.9 nM
For compound 4 the middle estimate is 57-fold (1.75 log units) above the measured one, outside the stated range (below it).
By their numbers in this assay, from the lowest: compound 4; then compounds 3, 1 and 2 (each within the scatter of the next).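

In this assay, for the compounds shown here, dimethylamino in place of acetyl on the aromatic carbon para to a large group gives a 65-fold lower number from compound 1 to compound 4 (1.82 log units; beyond the scatter) and so provides the first single-change step. It shows that this position responds strongly to the group it carries, which the earlier numbers, all within the scatter of one another, could not show, and that the response appears even though the two groups match in heavy-atom count and in hydrogen-bond acceptors and donors. Nothing in the data on hand bears on why this exchange has so large an effect.

From the compounds shown here alone, only acetyl and dimethylamino can be set against each other at this carbon on the core of compound 1, so it stays open whether a primary amine, a morpholine or a carboxylic acid there would give a number nearer compound 1 or compound 4. Going by these compounds, compound 3 also carries dimethylamino but differs from compound 4 in more than one place, so it remains open whether the step carries over to other versions of the core.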